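Replacing the Sulfamoyl Group with a Nitrile

The source may report more compounds than this note shows. Statements on the series, on what has been measured and on what is new or still open speak of the compounds shown alone.

Compound 3 `NS(=O)(=O)c1ccc(Nc2nncc3ccccc23)cc1` gives 33 nM in a functional assay on SF-268 cells (Homo sapiens) for antiproliferative activity, read by sulforhodamine B assay, with a stated time of 72 h (on this read-out higher numbers stand for weaker inhibition and lower numbers for stronger inhibition), the highest of the three numbers, yet within the scatter of compound 1 `Cc1cc(NS(=O)(=O)c2ccc(Nc3nncc4ccccc34)cc2)no1` at 24 nM and of compound 2 `O=S(=O)(Nc1ccccn1)c1ccc(Nc2nncc3ccccc23)cc1` at 25 nM. Compound 4 `N#Cc1ccc(Nc2nncc3ccccc23)cc1` differs from compound 3 by cyano in place of sulfamoyl on an aromatic carbon. Every measured step varies only the group on the sulfonamide nitrogen: a 1.0-fold higher number from compound 1 to compound 2 (0.02 log units; within the scatter), a 1.4-fold higher number from compound 1 to compound 3 (0.14 log units; within the scatter) and a 1.3-fold higher number from compound 2 to compound 3 (0.12 log units; within the scatter). None of them removes the sulfamoyl itself, so they bear only loosely on this change; they show that what sits on that nitrogen hardly matters. With the whole group gone, a moderate step in either direction remains possible, with a slight lean toward weaker inhibition. Compound 4 is therefore expected at 60 nM, between 20 nM and 200 nM, a step of a 1.8-fold higher number from compound 3 to compound 4 (0.26 log units; within the scatter).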

Compound 4, half-maximal inhibitory concentration: 3.3 nM
Compound 4: the middle estimate sits 18-fold (1.26 log units) above what was measured, outside the stated range (below it).
By their numbers in this assay, from the lowest: compound 4; then compounds 1, 2 and 3 (each within the scatter of the next).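

Every earlier step changed only the group on the sulfonamide nitrogen and stayed within the scatter, whereas replacing the whole sulfamoyl group with cyano on this aromatic carbon moves the result in this assay, with a 10-fold lower number from compound 3 to compound 4 (1.00 log units; beyond the scatter). The sulfamoyl group is therefore not required at this position, and stronger inhibition is reached without it. No measurement offered here explains the gain.

The compounds shown leave open whether the gain belongs to cyano alone. A carboxylic acid, an amine or a chlorine atom on the same carbon could show whether other replacements match it.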